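The compounds below may be only part of what the source reports. "The series", "measured", "known", "first", "only" and "open" are said of these compounds alone.

Compound 1 `CC(C)=CCn1nc(-c2cccnc2)c2ccccc2c1=O` gives 94%.
Compound 2 `O=C(O)CCCn1nc(-c2cccnc2)c2ccccc2c1=O` gives 73%.
Compound 3 `NCCn1nc(-c2cccnc2)c2ccccc2c1=O` gives 29%.

In an assay on isolated protein (Oryctolagus cuniculus) with Thromboxane-A synthase (Homo sapiens) as the target, tested at 1 uM (a higher number here means more inhibition at the concentration tested (going by the name of the read-out), a lower number less inhibition), compound 1 stands highest of the three numbers shown. The nearest number is a number 21 percentage points lower from compound 1 to compound 2 (beyond the scatter), the furthest a number 65 percentage points lower from compound 1 to compound 3 (beyond the scatter), and between the two lower compounds there is a number 44 percentage points lower from compound 2 to compound 3 (beyond the scatter). Compound 4 `CC(C)NC(=O)CCCn1nc(-c2cccnc2)c2ccccc2c1=O` has not yet been measured in this assay. It differs from compound 1 in one place: 2-(isopropylcarbamoyl)ethyl in place of 2-methylprop-1-en-1-yl on a saturated chain carbon bound to an aromatic nitrogen. For the measured compounds named here, two measured steps bear on this change, both starting from compound 1 and both replacing the same group on the same chain carbon: the step to compound 2 was modest, the step to compound 3 large. The entering 2-(isopropylcarbamoyl)ethyl group resembles the 2-carboxyethyl group of compound 2 far more than the aminomethyl group of compound 3, so a modest loss of about the size seen for compound 2 is expected, not the large one. Compound 4 is therefore expected to give 76%, with a range of 52% to 92%. The expected step is a number 18 percentage points lower from compound 1 to compound 4 (beyond the scatter).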

Compound 4, a percentage reported as inhibition, at one concentration (the size of the read-out at that concentration, not a potency): 89%
For compound 4 the middle estimate is 13 percentage points below the measured one; the range from low to high includes it.
By their numbers in this assay, from the lowest: compound 3; then compound 2; then compounds 4 and 1 (each within the scatter of the next).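

In this assay, the saturated chain carbon bound to an aromatic nitrogen accepts 2-(isopropylcarbamoyl)ethyl in place of 2-methylprop-1-en-1-yl, with a number 5 percentage points lower from compound 1 to compound 4 (within the scatter), so compound 4 shows what compound 2 and compound 3 did not: a replacement holding nitrogen and oxygen can leave the read-out within the scatter of compound 1. The chain end also matters, as isopropylamino in place of hydroxy on a carbonyl carbon gives a number 16 percentage points higher from compound 2 to compound 4 (beyond the scatter), and (isopropylcarbamoyl)methyl in place of amino gives a number 60 percentage points higher from compound 3 to compound 4 (beyond the scatter). Nothing available here explains these steps.

The compounds shown leave open whether a smaller amide, such as the methyl amide, or a methyl ester at the chain end would match compound 4. They also leave open how a longer chain carrying the same isopropyl amide would read.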